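Reversed amide linkage and lipophilicity within the series

A few compounds are considered here, and "the series" means these few. Any claim that something is new, unique, unknown or untested is made for them only; others in the source may bear on it.

Measured so far in a physicochemical assay for lipophilicity, at pH 7.4; a higher number here means a more lipophilic compound, a lower number a more polar compound:
- Compound 1 `Cc1cc(C(=O)O)nn1C(C)c1cc(Cl)ccc1OCc1ccccc1` gives 1.
- Compound 3 `Cc1cc(C(=O)NN2CCCCC2)nn1Cc1cc(Cl)ccc1OCC(C)C` gives 3.3.
- Compound 2 `Cc1cc(C(=O)NCc2ccccc2)nn1Cc1cc(Cl)ccc1OCc1ccccc1` reaches only an assay limit, > 3.7.

Compound 2 thus stands at the top of the numbers shown, but without a number of its own; (the limit of > 3.7 in this assay, at which 1 of the 3 values shown sits), so one of the three results is a limit rather than a value.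

Compound 4 `Cc1cc(NC(=O)c2ccccc2)nn1Cc1cc(Cl)ccc1OCc1ccccc1` is the next to be measured. It differs from compound 2 in one place: benzamido in place of benzylcarbamoyl on an aromatic carbon. Benzamido replaces benzylcarbamoyl on an aromatic carbon of the five-membered aromatic ring with two nitrogen, the group losing one carbon while keeping one hydrogen-bond donor and one hydrogen-bond acceptor.

Among the measured compounds shown here, no measured step in this assay is available for comparison. The expected step from compound 2 to compound 4 is a number at least 0.10 log units lower from compound 2 to compound 4 (that floor lies within the scatter), small and not clearly beyond the scatter, probably slightly downward. Compound 4 is therefore expected to give about 3.6 in this assay, between 3.2 and 4.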

Compound 4, distribution coefficient: > 3.7
Compound 4: only a limit was reported (the forecaster's own chance of this, stated with the estimate: 40%); middle value at least 0.10 log units away from the limit.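

In this assay compound 2 and compound 4 both reach only an assay limit, so no step can be read between them: the limit of > 3.7 in this assay, at which 2 of the 4 values shown sit.

The compounds shown leave open the size of any change in this assay with benzamido in place of benzylcarbamoyl on an aromatic carbon, including whether there is one.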